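Working notes: 3-bromophenyl in place of 4-ethylphenyl

The source may hold more compounds than are shown below. What is called first, only, known or untested is meant among the compounds shown, and "the series" means these compounds.

In an ADME assay on HCT-116 cells (Homo sapiens) for cytotoxicity, read by CellTiter-Glo, with a stated time of 72 h (on this read-out higher numbers stand for weaker inhibition and lower numbers for stronger inhibition), compound 3 (`CCc1ccc(S(=O)(=O)N2CCC(N3CCC(C)CC3)CC2)cc1`) gives > 5000 nM, a limit and not a number. Compound 1 (`COc1ccccc1-c1cccc(S(=O)(=O)N2CCC(N3CCC(C)CC3)CC2)c1`) gives > 5000 nM, also a limit. Compound 2 (`CC1CCN(C2CCN(S(=O)(=O)c3cnc(Cl)s3)CC2)CC1`) gives > 10000 nM, again a limit. The values therefore gather at two limits: the limit of > 10000 nM in this assay, at which 1 of the 3 values shown sits, and (the limit of > 5000 nM in this assay, at which 2 of the 3 values shown sit). Among the compounds with values here, the one measured step, a step that the two limits leave unreadable from compound 2 to compound 3, also changes the group on the sulfonyl sulfur, but gives no size to carry forward. Compound 4 (`CC1CCN(C2CCN(S(=O)(=O)c3cccc(Br)c3)CC2)CC1`) follows from 3-bromophenyl in place of 4-ethylphenyl on a sulfonyl sulfur. The expectation rests on compound 3, whose > 5000 nM is a limit. The estimated step that the limit leaves unreadable from compound 3 to compound 4 is expected to stay within the scatter in this assay, with no direction. Compound 4 is estimated at 8000 nM, with an expected range of 4000 nM to 15000 nM.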

Compound 4, half-maximal inhibitory concentration: > 5000 nM
Compound 4 was reported as a limit; the forecaster's own chance of this, stated with the estimate: 85%; the middle value lies beyond the limit too.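

Within the data shown here, compound 4 is reported only as a limit, as are compound 1, compound 2 and compound 3, so no step among them can be read. The compounds shown leave open whether the group on the sulfonyl sulfur changes cytotoxicity at all.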